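The compounds below may be only part of what the source reports. "The series", "measured", "known", "first", "only" and "open" are said of these compounds alone.

Series notes. Among the measured compounds shown here, in an assay for inhibition of Fatty-acid amide hydrolase 1 (Rattus norvegicus) (on this read-out lower numbers stand for stronger inhibition and higher numbers for weaker inhibition), compound 1 `O=C(CCc1ccc(-c2ccccc2)cc1)c1ncc(-c2cccc(-c3nnn[nH]3)n2)o1` gives 25 nM, the higher of the two numbers measured so far. For the measured compounds named here, compound 2 `COC(=O)c1ccc(-c2cnc(C(=O)CCc3ccc(COc4ccccc4)cc3)o2)nc1` gives 3.5 nM in this assay, a lower number that lies beyond the scatter; compound 2 differs from compound 1 in more than one place, so no single step can be drawn between them. Compound 3 `CCOC(=O)c1cccc(-c2cnc(C(=O)CCc3ccc(-c4ccccc4)cc3)o2)n1` differs from compound 1 by ethoxycarbonyl in place of 1H-tetrazol-5-yl on an aromatic carbon. Going by the values given here, no measured pair isolates this change. A modest step toward a lower number is expected, a 2.5-fold lower number from compound 1 to compound 3 (0.40 log units; beyond the scatter), though a result within the scatter of compound 1 would not surprise. Compound 3 is estimated at 10 nM, within the range 2 nM to 50 nM.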

Compound 3, inhibition constant: 3 nM
Compound 3: middle estimate off by 3.3-fold (0.52 log units), on the high side, and the stated range covers the measured number.
By their numbers in this assay, from the lowest: compounds 3 and 2 (each within the scatter of the next); then compound 1.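

In this assay, ethoxycarbonyl in place of 1H-tetrazol-5-yl, on the aromatic carbon next to the ring nitrogen, gives an 8.3-fold lower number from compound 1 to compound 3 (0.92 log units; beyond the scatter) at the same count of 5 heavy atoms, so the number at this position depends on the group it carries. The five-membered aromatic ring and its hydrogen-bond donor are not required for a low number here. Nothing measured explains the shift.

Still open, from the compounds shown here alone, is how far the result depends on the ester itself. A carboxylic acid or a primary amide at this position on the core of compound 3 would bear on that.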